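Nitro-to-bromo exchange on two cores, breast cancer cell growth

This account rests on a few compounds, and the source may have more. Where it says the series, first, only, none or still open, it means among the compounds named here.

Measured in a functional assay on MCF7 cells (Homo sapiens) for inhibition, read by sulforhodamine B assay, with a stated time of 48 h; a higher number here means a weaker inhibitor of growth, a lower number a stronger inhibitor of growth:
compound 1 `N#CCC1=NN=C(c2ccc(Br)cc2)C(CC(=O)c2ccc([N+](=O)[O-])cc2)O1` gives 32000 nM
compound 2 `N#CCC1=NN=C(c2ccc([N+](=O)[O-])cc2)C(CC(=O)c2ccc([N+](=O)[O-])cc2)O1` gives 1600 nM
compound 3 `N#CCC1=C(C#N)CC(c2ccc([N+](=O)[O-])cc2)=C(CC(=O)c2ccc([N+](=O)[O-])cc2)O1` gives 30 nM

One change is known on the first core: bromo in place of nitro on an aromatic carbon. It made a 20-fold higher number from compound 2 to compound 1 (1.30 log units; beyond the scatter) in this assay.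

Compound 3 sits on a different core; the difference between the two cores is not broken down here. Compound 3 stands lowest of the three numbers, beyond the scatter against both compound 1 and compound 2.

Compound 4 `N#CCC1=C(C#N)CC(c2ccc(Br)cc2)=C(CC(=O)c2ccc([N+](=O)[O-])cc2)O1` carries the same change on the core of compound 3: bromo in place of nitro on an aromatic carbon. Since the two place descriptions agree word for word, this is taken as the same change. For compound 4 a step of a 17-fold higher number from compound 3 to compound 4 (1.22 log units; beyond the scatter) in this assay is expected, resting on compound 2 to compound 1 having shown a 20-fold higher number from compound 2 to compound 1 (1.30 log units; beyond the scatter), with wider bounds because the core differs. Compound 4 is estimated at 500 nM, between 100 nM and 2500 nM.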

Compound 4, concentration for 50% growth inhibition: 90 nM
Estimate against measurement, compound 4: 5.6-fold (0.74 log units) above; measured number below the stated range.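

In this assay the exchange of 4-nitrophenyl for 4-bromophenyl again gives a higher number on the second core, a 3.0-fold higher number from compound 3 to compound 4 (0.48 log units; beyond the scatter), so the direction holds on both cores shown. The size of the step does not carry over: the same change on two cores in this assay, a 20-fold higher number (1.30 log units; beyond the scatter) from compound 2 to compound 1 and a 3.0-fold higher number (0.48 log units; beyond the scatter) from compound 3 to compound 4, 6.7-fold (0.82 log units) apart, beyond the scatter of two such steps. Two cores show that a step measured on one core is a poor guide to its size on the other, but they do not show what sets that size or what the step would be on a third core.

Still open, on these data alone, is how an amine or a carboxylic acid would compare with nitro and bromo at this place. Also open, as far as these compounds go, is what replacing the second nitro group, common to all four compounds, with bromo would do.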